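Halogen Swap on a Pair of Weakly Active Amides

The source may hold more compounds than are shown below. What is called first, only, known or untested is meant among the compounds shown, and "the series" means these compounds.

Compound 1 `Cc1ccc(C(=O)Nc2cccc3cccnc23)cn1` gives > 10000 nM in a functional assay on MIA PaCa-2 cells (Homo sapiens) for inhibition, read by MTT assay, with a stated time of 72 h (on this read-out higher numbers stand for weaker inhibition and lower numbers for stronger inhibition), which is a limit of the assay.
Compound 2 `O=C(Nc1cccc2cccnc12)c1ccc(Br)nc1` gives > 10000 nM in this assay, again a limit.

Compound 2 therefore stands at the limit, as does every value shown, (the limit of > 10000 nM in this assay, at which 2 of the 2 values shown sit). Compound 3 `O=C(Nc1cccc2cccnc12)c1ccc(F)nc1` differs from compound 2 by fluoro in place of bromo on an aromatic carbon. For the measured compounds named here, the only measured step, a step that the two limits leave unreadable from compound 1 to compound 2, cannot be read because both of its ends sit at the limit of > 10000 nM in this assay, at which 2 of the 2 values shown sit. Going by the values given here, no step in this assay beyond the scatter can be foreseen from these numbers. Compound 3 is thus expected at 15000 nM, with a range from 4000 nM to 60000 nM, most likely reported as another limit. The expected step is a step that the limit leaves unreadable from compound 2 to compound 3.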

Compound 3, half-maximal inhibitory concentration: > 10000 nM
Compound 3: no number, only a limit; the forecaster's own chance of this, stated with the estimate: 80%; the middle value lies beyond the limit too.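

No new step can be read among compound 1, compound 2 and compound 3, because all three sit at the same limit: the limit of > 10000 nM in this assay, at which 3 of the 3 values shown sit.

The compounds shown leave open whether methyl, bromo and fluoro differ at all in inhibition.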